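Piperazine substituent swaps on the shared thiazolidinone core

The source may report more compounds than this note shows. Statements on the series, on what has been measured and on what is new or still open speak of the compounds shown alone.

Measured compounds:
- compound 1, `COC(=O)c1ccc(C2SCC(=O)N2c2ccc(N3CCN(S(=O)(=O)c4ccccc4)CC3)cn2)c(OC)c1`: 48400 nM
- compound 2, `COC(=O)c1ccc(C2SCC(=O)N2c2ccc(N3CCN(Cc4cccc(C)c4)CC3)cn2)c(OC)c1`: 27300 nM
- compound 3, `COC(=O)c1ccc(C2SCC(=O)N2c2ccc(N3CCN(S(=O)(=O)c4cc(Cl)ccc4Cl)CC3)cn2)c(OC)c1`: 27400 nM

All three share one core and differ only in the group on the piperazine nitrogen. In a functional assay on NALM-6 cells (Homo sapiens) for antiproliferative activity, read by MTT assay and trypan blue exclusion, with a stated time of 72 h (on this read-out lower numbers stand for stronger inhibition and higher numbers for weaker inhibition), compound 1 gives 48400 nM, compound 2 gives 27300 nM and compound 3 gives 27400 nM. Compound 3 stands second highest of the three numbers, but its nearest neighbour is compound 2 and the gap to compound 1 is also within the scatter, so no order among the three can be read from these values.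

The next compound is compound 4, `COC(=O)c1ccc(C2SCC(=O)N2c2ccc(N3CCN(Cc4ccc(Cl)c(Cl)c4)CC3)cn2)c(OC)c1`. Its change from compound 3 is 3,4-dichlorobenzyl in place of (2,5-dichlorophenyl)sulfonyl on an amine nitrogen in a ring.

For the measured compounds named here, two measured steps bear on this: a 1.8-fold lower number from compound 1 to compound 2 (0.25 log units; within the scatter), and a 1.0-fold higher number from compound 2 to compound 3 (0.00 log units; within the scatter). The first exchanges a sulfonyl-linked aryl for a benzyl, the second does the reverse with a dichlorinated aryl; neither moved the number beyond the scatter. Moving from compound 3 to compound 4 again exchanges a sulfonyl-linked dichlorophenyl for a dichlorobenzyl, so no step beyond the scatter is expected in this assay, in either direction.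

Compound 4 is therefore estimated at 27000 nM, with a range from 9000 nM to 80000 nM, which amounts to an expected step of a 1.0-fold lower number from compound 3 to compound 4 (0.01 log units; within the scatter).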

Compound 4, half-maximal inhibitory concentration: > 100000 nM
Compound 4 ended at the assay's limit; the forecaster's own chance of this, stated with the estimate: 15%; middle value at least 3.7-fold (0.56 log units) from the limit.
By their numbers in this assay, from the lowest: compounds 2, 3 and 1 (each within the scatter of the next). At a limit, above all of these: compound 4.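

Compound 4 gives a limit of the assay in this assay, not a number: the limit of > 100000 nM in this assay, at which 1 of the 4 values shown sits.

This position is therefore not indifferent to its substituent, as the earlier swaps might have suggested: 3,4-dichlorobenzyl in place of (2,5-dichlorophenyl)sulfonyl gives an at least 3.6-fold higher number from compound 3 to compound 4 (0.56 log units; beyond the scatter), and 3,4-dichlorophenyl in place of 3-methylphenyl on a saturated chain carbon bound to an amine nitrogen in a ring gives an at least 3.6-fold higher number from compound 2 to compound 4 (0.56 log units; beyond the scatter). The change from phenylsulfonyl to 3,4-dichlorobenzyl also lies beyond the scatter, at an at least 2.0-fold higher number from compound 1 to compound 4 (0.31 log units; beyond the scatter), yet the benzyl group alone does not set the outcome, since compound 2 also carries a benzyl group and stays within the scatter of compound 1 and compound 3.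

The shift in compound 4 cannot be assigned to either chlorine or to the pair, and a plain benzyl, a 3-chlorobenzyl or a 4-chlorobenzyl on the same nitrogen would separate those readings. The limit also leaves the true size of all three steps open, so only their lower bounds can be used in comparing this group with any other.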